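This account rests on a few compounds, and the source may have more. Where it says the series, first, only, none or still open, it means among the compounds named here.

Measured so far in a functional assay on SK-BR-3 cells (Homo sapiens) for antiproliferative activity, read by XTT assay, with a stated time of 72 h; on this read-out lower numbers stand for stronger inhibition and higher numbers for weaker inhibition:
compound 1 `COc1ccc(-c2cc3ccccc3nc2/C=C/C(=O)c2ccc(OC)cc2OC)cc1` gives 2260 nM
compound 2 `COc1ccc(-c2cc3ccccc3nc2/C=C/C(=O)c2ccco2)cc1` gives 640 nM

Among the measured compounds shown here, compound 2 stands lowest of the two numbers in this assay; the only measured step is a 3.5-fold lower number from compound 1 to compound 2 (0.55 log units; beyond the scatter), which exchanges the whole aryl group on the carbonyl carbon.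

Compound 3 `COc1ccc(-c2cc3ccccc3nc2/C=C/C(=O)c2cccs2)cc1` differs from compound 2 by thiophen-2-yl in place of furan-2-yl on a carbonyl carbon. For the measured compounds named here, no measured step covers this exchange: the single known step replaces a substituted benzene by furan-2-yl and says little about one heteroaryl replacing another of the same ring size. With only the comparable attachment point and ring count as guidance, the expected change for compound 3 in this assay is a 1.2-fold lower number from compound 2 to compound 3 (0.07 log units; within the scatter), i.e. nothing beyond the scatter, leaning if anything slightly toward a lower number. Compound 3 is therefore estimated at 550 nM, with a range of 220 nM to 1400 nM.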

Compound 3, half-maximal inhibitory concentration: 800 nM
Compound 3: the middle estimate sits 1.5-fold (0.16 log units) below what was measured; the range from low to high includes it.
By their numbers in this assay, from the lowest: compounds 2 and 3 (each within the scatter of the next); then compound 1.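

In this assay, exchanging furan-2-yl for thiophen-2-yl on the carbonyl carbon leaves the number within the scatter (a 1.3-fold higher number from compound 2 to compound 3 (0.10 log units; within the scatter)), so at this position the two rings cannot be told apart. The step away from the 2,4-dimethoxyphenyl group holds with the second heteroaryl as well (a 2.8-fold lower number from compound 1 to compound 3 (0.45 log units; beyond the scatter)), which means the lower number is no longer tied to furan-2-yl alone. Nothing available explains why the oxygen and sulfur rings read alike.

The compounds shown do not separate the contribution of the two methoxy groups from that of the ring itself, which a plain phenyl or a 4-methoxyphenyl on the same carbonyl carbon would address. Also open, from the compounds shown here alone, is whether the position tolerates a six-membered heteroaryl such as pyridin-2-yl, or a saturated ring such as tetrahydrofuran-2-yl.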